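The source may report more compounds than this note shows. Statements on the series, on what has been measured and on what is new or still open speak of the compounds shown alone.

Measured so far in an ADME assay on Huh-7 cells (Homo sapiens) for cytotoxicity; on this read-out lower numbers stand for higher toxicity in this test and higher numbers for lower toxicity in this test:

- compound 1, `Cc1ccccc1-c1nn(-c2ccc(F)cc2F)cc1CN1CCN(c2ccccc2)CC1`: > 20000 nM
- compound 2, `Cc1ccccc1-c1nn(-c2ccc(F)cc2F)cc1CNCc1ccncc1`: > 20000 nM

Both values are limits of this assay, not numbers. Compound 1 reports only a limit, > 20000 nM. Compound 2 likewise reports only a limit, > 20000 nM. Compound 2 therefore stands where every value in the series stands so far, namely at the limit of > 20000 nM in this assay, at which 2 of the 2 values shown sit, and no ordering among the two compounds can be read from these results. Among the measured compounds shown here, no step between two measured compounds is available.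

Compound 3, `Cc1ccccc1-c1nn(-c2ccc(F)cc2F)cc1CN1CCN(C(C)C)CC1`, is the next compound to be measured in this assay. Its change from compound 2 is 4-isopropylpiperazin-1-yl in place of ((pyridin-4-yl)methyl)amino on a saturated chain carbon bound to an aromatic carbon. The rest of the structure, the shared core of compound 2, is unchanged.

With the two measured compounds both sitting at the limit of > 20000 nM in this assay, at which 2 of the 2 values shown sit, there is no basis in the series for expecting a shift in either direction. The step from compound 2 to compound 3 is estimated as a step that the limit leaves unreadable from compound 2 to compound 3, that is, none beyond the usual scatter of this assay. Compound 3 is accordingly expected to come out at 30000 nM, with a range from 10000 nM to 100000 nM, and most probably to be reported again only as a limit.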

Compound 3, half-maximal cytotoxic concentration: > 20000 nM
Compound 3 gave a limit, no number; the forecaster's own chance of this, stated with the estimate: 80%; the middle value does not contradict the limit.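

In this assay compound 3 again reports only a limit, so no new step can be read from compound 2 to compound 3 or from compound 1 to compound 3, all three compounds sitting at one limit: the limit of > 20000 nM in this assay, at which 3 of the 3 values shown sit.

The compounds shown leave open how far compound 1, compound 2 and compound 3 lie from one another in this assay, and whether any change on the shared core would give a number rather than a limit.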